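Fluoro for Chloro on a Core Without Measured Cytotoxicity

The source may hold more compounds than are shown below. What is called first, only, known or untested is meant among the compounds shown, and "the series" means these compounds.

Of the compounds shown here, three built on one shared core have been tested in a toxicity assay on HeLa cells (Homo sapiens) for cytotoxicity, read by MTT assay, with a stated time of 48 h; a lower number here means a stronger inhibitor of growth, a higher number a weaker inhibitor of growth. Compound 1 `O=C1NC(=S)S/C1=C\c1cc2cc(Cl)ccc2nc1Cl` carries a chloro group on the carbon-only ring of its fused system. In this assay compound 1 gives > 100 ug/mL, which is a limit of the assay rather than a number. Compound 2 `Cc1cccc2cc(/C=C3\SC(=S)NC3=O)c(Cl)nc12` gives > 100 ug/mL in this assay, again a limit. Compound 3 `COc1ccc2cc(/C=C3\SC(=S)NC3=O)c(Cl)nc2c1` gives > 100 ug/mL in this assay, also a limit. Compound 1 therefore stands at the limit of > 100 ug/mL in this assay, at which 3 of the 3 values shown sit, with nothing to set it apart from the other two.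

Compound 4 `O=C1NC(=S)S/C1=C\c1cc2cc(F)ccc2nc1Cl` differs from compound 1 by fluoro in place of chloro on an aromatic carbon. For the measured compounds named here, no pair among the measured compounds differs in a single place, so the data give no measured step to lean on. With compound 1 at > 100 ug/mL, no measurable growth inhibition is expected for compound 4 either, and the step from compound 1 to compound 4 is expected to be a step that the limit leaves unreadable from compound 1 to compound 4, that is, none beyond the scatter. Compound 4 is estimated at 150 ug/mL in this assay, within a range from 60 ug/mL to 400 ug/mL, most likely reported once more as a limit.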

Compound 4, concentration for 50% growth inhibition: > 100 ug/mL
Compound 4: no number, only a limit; the forecaster's own chance of this, stated with the estimate: 85%; the middle value lies beyond the limit too.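

Compound 1 and compound 4 are both reported only as limits in this assay, so no step can be read between them: the limit of > 100 ug/mL in this assay, at which 4 of the 4 values shown sit.

The compounds shown leave open whether anything on the shared core gives measurable growth inhibition, and whether fluoro in place of chloro on an aromatic carbon makes any difference.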